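This account rests on a few compounds, and the source may have more. Where it says the series, first, only, none or still open, it means among the compounds named here.

Compound 1 `Cc1ccc(N2C(=O)C/C(=C\c3cccc(C(=O)Nc4cccc(F)c4)c3)C2=O)cc1` carries a methyl on one of its outer rings and was tested in an ADME assay on NCM460 cells (Homo sapiens) for cytotoxicity, read by MTT assay, with a stated time of 72 h; on this read-out lower numbers stand for stronger inhibition and higher numbers for weaker inhibition. In this assay compound 1 gives > 100000 nM, which is a limit of the assay and not a number. Two companions were run alongside it. Compound 2 `Cc1ccc(NC(=O)c2cccc(/C=C3\CC(=O)N(c4ccccc4)C3=O)c2)cc1C` was tested in this assay and gives > 100000 nM, again a limit. Compound 3 `COc1ccc(NC(=O)c2cccc(CC3CC(=O)N(c4ccc(C)cc4)C3=O)c2)cc1`, in which the double bond to the core is replaced by a single bond, was tested in this assay and gives > 100000 nM, also a limit. For the measured compounds named here, compound 1 therefore stands exactly where the other two stand: every value so far sits at the limit of > 100000 nM in this assay, at which 3 of the 3 values shown sit, and no number separates any of them.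

Compound 4 `O=C(Nc1cccc(F)c1)c1cccc(/C=C2\CC(=O)N(c3ccccc3)C2=O)c1` has not been measured yet. It differs from compound 1 in one place only: hydrogen in place of methyl on an aromatic carbon. With nothing but limits on record, the step from compound 1 to compound 4 is expected to be none beyond the scatter, that is a number no higher from compound 1 to compound 4 (the limit leaves the size open). In this assay compound 4 is expected to give about 100000 nM, somewhere between 40000 nM and 250000 nM, and most likely the assay will again report only a limit.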

Compound 4, half-maximal inhibitory concentration: > 100000 nM
Compound 4: only a limit was reported (the forecaster's own chance of this, stated with the estimate: 85%); the middle value sits exactly at the limit.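

No step from compound 1 or compound 2 to compound 4 can be read in this assay, because each value shown is a limit of the assay and not a number: the limit of > 100000 nM in this assay, at which 4 of the 4 values shown sit.

The compounds shown leave open whether any of them affects these cells at all, and whether removing the methyl changes anything.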